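The source may report more compounds than this note shows. Statements on the series, on what has been measured and on what is new or still open speak of the compounds shown alone.

Measured in a functional assay on HL-60 cells (Homo sapiens) for cytotoxicity, read by XTT assay, with a stated time of 6 days; a higher number here means a weaker inhibitor, a lower number a stronger inhibitor:
- compound 1 `CNc1ncnc2[nH]cc(Sc3cccs3)c12`: 13500 nM
- compound 2 `Nc1ncnc2[nH]cc(Sc3cccs3)c12`: 13900 nM
- compound 3 `c1csc(Sc2c[nH]c3ncnc(-c4cccs4)c23)c1`: 21100 nM

In this assay, compound 3 cannot be told apart from the other two compounds: the record shows a 1.6-fold higher number from compound 1 to compound 3 (0.19 log units; within the scatter) and a 1.5-fold higher number from compound 2 to compound 3 (0.18 log units; within the scatter). Compound 4 `Cc1ncnc2[nH]cc(Sc3cccs3)c12` carries methyl in place of thiophen-2-yl on an aromatic carbon. The two steps just cited bear most directly on this change, since each exchanges the group on that same carbon. The remaining step, a 1.0-fold higher number from compound 1 to compound 2 (0.01 log units; within the scatter), alters only the methyl on the nitrogen. None of the three leaves the scatter, so no step beyond the scatter is expected here. The expected step is a 1.4-fold lower number from compound 3 to compound 4 (0.15 log units; within the scatter). For compound 4 the estimated value is 15000 nM, with an expected range of 7000 nM to 32000 nM.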

Compound 4, half-maximal inhibitory concentration: > 25000 nM
Compound 4: a limit, no number (the forecaster's own chance of this, stated with the estimate: 10%); at least 1.6-fold (0.22 log units) between middle value and limit.
By their numbers in this assay, from the lowest: compounds 1, 2 and 3 (each within the scatter of the next). At a limit, above all of these: compound 4.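

In this assay compound 4 gives a limit and not a number: the limit of > 25000 nM in this assay, at which 1 of the 4 values shown sits.

On this aromatic carbon, thiophen-2-yl, amino and methylamino all gave numbers, while methyl gave only a limit, with an at least 1.1-fold higher number from compound 3 to compound 4 (0.07 log units; that floor lies within the scatter), an at least 1.7-fold higher number from compound 2 to compound 4 (0.25 log units; that floor lies within the scatter) and an at least 1.8-fold higher number from compound 1 to compound 4 (0.26 log units; that floor lies within the scatter). Each of these floors lies within the scatter, so methyl is not shown to differ from the other three groups.

On these data alone, how far compound 4 truly lies from the other compounds stays open. Also open, as far as these compounds go, is what a longer chain such as ethyl, or a carboxylic acid, would give on this carbon in this assay.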